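The compounds below may be only part of what the source reports. "The series", "measured", "known", "first", "only" and "open" are said of these compounds alone.

Measured so far:
compound 1, `COc1cc(O)c(C(=O)/C=C/c2ccc(F)cc2)c(OC)c1`, gives 12400 nM
compound 2, `COc1cccc(/C=C/C(=O)c2c(OC)cc(OC)cc2OC)c1`, gives 4300 nM
compound 3, `COc1cc(OC)c(C(=O)/C=C/c2ccc(Cl)cc2)c(OC)c1`, gives 5400 nM

All three were read in a functional assay on HCT-116 cells (Homo sapiens) for cytotoxicity, with a stated time of 48 h; on this read-out lower numbers stand for stronger inhibition and higher numbers for weaker inhibition. Among the three numbers, compound 3 gives the second highest: compound 2 lies within the scatter of it, while compound 1 stands beyond the scatter, at the higher end. For the measured compounds named here, the only single-point step measured between these compounds, a 1.3-fold higher number from compound 2 to compound 3 (0.10 log units; within the scatter), exchanges the whole aryl group at the far end of the chain and still stays within the scatter.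

The next compound, compound 4, `COc1cc(OC)c(C(=O)/C=C/c2ccc(Br)cc2)c(OC)c1`, differs from compound 3 in one place: bromo in place of chloro on an aromatic carbon. Going by the values given here, no measured step swaps one halogen for another at this position, so the expectation rests on the single step at this end of the molecule, which was within the scatter even for a larger exchange. Compound 4 is therefore expected to show a step of a 1.1-fold lower number from compound 3 to compound 4 (0.03 log units; within the scatter) relative to compound 3, nothing beyond the scatter. Compound 4 is estimated at 5000 nM in this assay, with a range from 2300 nM to 11000 nM.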

Compound 4, half-maximal inhibitory concentration: 6200 nM
Compound 4: the middle estimate sits 1.2-fold (0.09 log units) below what was measured; the measured number falls inside the stated range.
By their numbers in this assay, from the lowest: compounds 2, 3, 4 and 1 (each within the scatter of the next, the first and the last beyond it).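

In this assay the exchange of one halogen for another at this position can now be read directly: bromo in place of chloro on the aromatic carbon gives a 1.1-fold higher number from compound 3 to compound 4 (0.06 log units; within the scatter), so this swap leaves the two compounds indistinguishable. The wider exchange of 4-bromophenyl in place of 3-methoxyphenyl gives a 1.4-fold higher number from compound 2 to compound 4 (0.16 log units; within the scatter), which adds a second exchange of the whole aryl group that stays within the scatter. Among compound 2, compound 3 and compound 4, then, this read-out does not separate the three aryl groups at the far end of the chain.

Going by these compounds, whether an amine or a carboxylic acid on this aromatic carbon would move the number beyond the scatter remains open. No evidence at hand bears on why these exchanges stay so close.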